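A few compounds are considered here, and "the series" means these few. Any claim that something is new, unique, unknown or untested is made for them only; others in the source may bear on it.

Measured so far in a functional assay (Nicotiana tabacum); a lower number here means a stronger inhibitor, a higher number a weaker inhibitor:
compound 1 `CCCNc1nc(SC)nc2ncccc12`, 270 nM
compound 2 `CCCCCCNc1nc(SC)nc2ncccc12`, 3330 nM

Compound 2 stands at the higher of the two numbers measured in this assay, well apart from compound 1. Among the compounds with values here, the only step known is a 12-fold higher number from compound 1 to compound 2 (1.09 log units; beyond the scatter), a large move to weaker inhibition when the chain on the ring nitrogen is lengthened.

Compound 3 `CCC(CC)Nc1nc(SC)nc2ncccc12` is not yet measured. Its change from compound 2 is pentan-3-yl in place of hexyl on a nitrogen on an aromatic ring. The new chain is shorter than that of compound 2 and branched at the point of attachment, so it sits between compound 1 and compound 2 in chain length. Within the data shown here, the step from compound 1 to compound 2 bears on this directly: shortening the chain is expected to pull the number back down, though branching has no precedent here, so only part of that gap is assumed to be recovered. The estimated step is a 2.6-fold lower number from compound 2 to compound 3 (0.41 log units; beyond the scatter), toward a lower number and beyond the scatter. Compound 3 is expected to give about 1300 nM in this assay, with a range from 450 nM to 4000 nM.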

Compound 3, half-maximal inhibitory concentration: 2720 nM
Compound 3: middle estimate off by 2.1-fold (0.32 log units), on the low side; low and high end bracket the measured number.
By their numbers in this assay, from the lowest: compound 1; then compounds 3 and 2 (each within the scatter of the next).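

In this assay, pentan-3-yl in place of hexyl on a nitrogen on an aromatic ring gives a 1.2-fold lower number from compound 2 to compound 3 (0.09 log units; within the scatter) and so leaves compound 2 and compound 3 indistinguishable, which means that branching at the attachment carbon and the shorter named chain together bring no measurable recovery here. The comparison with the smaller group gives a 10-fold higher number from compound 1 to compound 3 (1.00 log units; beyond the scatter) and, read with a 12-fold higher number from compound 1 to compound 2 (1.09 log units; beyond the scatter) from the earlier pair, shows that the loss is not confined to the straight hexyl chain but also appears with a branched chain, leaving compound 1 as the most potent of the three. Within the data shown here, these potency numbers show only that the two larger groups match in this read-out, and no further data bear on the result.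

The compounds shown do not separate the contribution of chain length from that of branching, a question that straight butyl and pentyl chains or a small branched isopropyl group on the same nitrogen would address. Also open, as far as these compounds go, is whether a cyclic group such as cyclopentyl, or a chain ending in a hydroxyl or an amine, would keep the number near the higher pair or near that of compound 1 at 270 nM.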